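A few compounds are considered here, and "the series" means these few. Any claim that something is new, unique, unknown or untested is made for them only; others in the source may bear on it.

Working notes on the series in a functional assay on HT-1080 cells (Homo sapiens) for cytotoxicity, read by MTT assay, with a stated time of 72 h; on this read-out lower numbers stand for stronger inhibition and higher numbers for weaker inhibition. Compound 1 `COc1cc(Nc2nc(C(=N)Nc3ccc(N4CCN(C)CC4)cc3)cc3c(-c4ccccc4)n[nH]c23)cc(OC)c1OC` gives 3400 nM in this assay. Compound 2 `CN1CCN(c2ccc(NC(=N)c3cc4cn[nH]c4cn3)cc2)CC1`, which keeps neither the phenyl on the shared core nor the substituted amine, gives 31300 nM. Compound 3 `COc1cc(Nc2nc(C(=N)Nc3ccccc3)cc3c(-c4ccccc4)n[nH]c23)cc(OC)c1OC` gives 3900 nM and stands second highest of the three numbers, nearest compound 1 and furthest from compound 2. Among the compounds with values here, the one measured step, a 1.1-fold higher number from compound 1 to compound 3 (0.06 log units; within the scatter), concerns a substituent on an aromatic carbon elsewhere in the molecule and lies within the scatter. Compound 4 `N=C(Nc1ccccc1)c1cc2c(-c3ccccc3)n[nH]c2c(NC2CCCCC2)n1` differs from compound 3 by cyclohexyl in place of 3,4,5-trimethoxyphenyl on a nitrogen on an aromatic ring. Within the data shown here, no measured step touches this nitrogen; the only comparison that reaches it is compound 2, whose number is higher than that of compound 3 after removal of more than one group at once, so it gives no clean read. Without a precedent, a modest rise in the number, or none beyond the scatter, is expected. For compound 4 the expected step is a 1.5-fold higher number from compound 3 to compound 4 (0.19 log units; within the scatter). Compound 4 is estimated at 6000 nM, within 2500 nM to 15000 nM.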

Compound 4, half-maximal inhibitory concentration: 850 nM
Compound 4: middle estimate off by 7.1-fold (0.85 log units), on the high side; measured number outside the range, below it.
By their numbers in this assay, from the lowest: compound 4; then compounds 1 and 3 (each within the scatter of the next); then compound 2.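

In this assay the nitrogen on an aromatic ring responds to a single change beyond the scatter: cyclohexyl in place of 3,4,5-trimethoxyphenyl gives a 4.6-fold lower number from compound 3 to compound 4 (0.66 log units; beyond the scatter) in a series whose only earlier one-place step stayed within the scatter. The 3,4,5-trimethoxyphenyl group is therefore not needed on this nitrogen for the number seen with compound 3, and a six-membered non-aromatic ring of carbon only, with no hydrogen-bond acceptors, gives the lower number. Nothing measured alongside this step offers a reason for it.

Compound 3 and compound 4 alone do not separate the loss of the aromatic ring from the loss of the three methoxy groups. Plain phenyl, cyclopentyl or an open chain such as n-hexyl on this nitrogen would bear on that question, and whether the lower number holds with 4-methylpiperazin-1-yl on the anilide ring remains open.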